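A few compounds are considered here, and "the series" means these few. Any claim that something is new, unique, unknown or untested is made for them only; others in the source may bear on it.

Measured so far:
compound 1, `O=C(COc1nn(-c2ccccc2F)c2ccc(F)cc12)N1CCOCC1`, 1.6 h
compound 2, `CC(C)(C)OC(=O)N1CCN(c2cccc3c2cnn3-c2ccccc2F)C1=O`, 2 h
compound 3, `O=C1NCCN1CCOc1nn(-c2ccccc2F)c2ccc(F)cc12`, 0.4 h

These three compounds share a core and were tested in an ADME assay on the whole organism (strain Sprague-Dawley) for metabolic stability, with Rattus norvegicus as the target, read by LC-MS; on this read-out lower numbers stand for a shorter-lived compound and higher numbers for a longer-lived compound. Compound 2 and compound 1 give numbers that lie within the usual scatter of each other, so they cannot be told apart; compound 3 gives a clearly lower number than compound 2, a gap beyond the scatter. Within the data shown here, the one single-site change measured so far is a 4.0-fold lower number from compound 1 to compound 3 (0.60 log units; beyond the scatter).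

Compound 4, `O=C1N(Cc2ncco2)CCN1c1cccc2c1cnn2-c1ccccc1F`, is made from compound 2 by one change: (1,3-oxazol-2-yl)methyl in place of tert-butoxycarbonyl on an amide-type nitrogen in a ring. Among the measured compounds shown here, no measured step touches this ring nitrogen; the step from compound 1 to compound 3 alters a group at a different place, so it offers only a loose guide to how large a change of group can move the number in this assay. For the measured compounds named here, with no direct precedent, the step from compound 2 to compound 4 is expected to be small, a 1.7-fold lower number from compound 2 to compound 4 (0.22 log units; within the scatter), and not clearly beyond the scatter. Compound 4 is therefore estimated at 1.2 h, within a range from 0.4 h to 3.2 h.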

Compound 4, half-life: 1.1 h
Estimate against measurement, compound 4: 1.1-fold (0.04 log units) above, within the range that was stated.
By their numbers in this assay, from the lowest: compound 3; then compounds 4, 1 and 2 (each within the scatter of the next).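

Among these compounds, at this amide-type nitrogen in a ring, (1,3-oxazol-2-yl)methyl in place of tert-butoxycarbonyl gives a 1.8-fold lower number from compound 2 to compound 4 (0.26 log units; within the scatter) in this assay, the first reading at this position. The swap is not a small one on paper: a group with no ring leaves and a five-membered aromatic ring with 2 hetero atoms enters, yet the two numbers cannot be told apart, so at least this one replacement at this nitrogen leaves the half-life within the usual scatter. Nothing available explains why the number holds here.

One replacement cannot show how widely that holds at this nitrogen. On these data alone, whether a plain methyl, a chain ending in an amine or one ending in a carboxylic acid would also stay within the scatter remains open.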